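Swapping 3-methylphenyl for 4-cyano-3-fluorophenyl on a shared core

The source may hold more compounds than are shown below. What is called first, only, known or untested is meant among the compounds shown, and "the series" means these compounds.

In a toxicity assay on MT4 cells (Homo sapiens) for cytotoxicity, read by MTT assay (on this read-out lower numbers stand for higher toxicity in this test and higher numbers for lower toxicity in this test), compound 1 (`Cc1cc(-c2ccccc2F)cc(C)c1Oc1cc(N)nc(Nc2ccc(C#N)cc2)n1`) gives 29300 nM as its reading, compound 2 (`Cc1cc(-c2ccc(F)cc2)cc(C)c1Oc1cc(N)nc(Nc2ccc(C#N)cc2)n1`) gives 23100 nM as its reading, and compound 3 (`Cc1cccc(-c2cc(C)c(Oc3cc(N)nc(Nc4ccc(C#N)cc4)n3)c(C)c2)c1`) gives 27600 nM as its reading. Its place among these three numbers means little: the steps are a 1.1-fold lower number from compound 1 to compound 3 (0.03 log units; within the scatter) and a 1.2-fold higher number from compound 2 to compound 3 (0.08 log units; within the scatter) and neither separates it from the others.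

Compound 4 (`Cc1cc(-c2ccc(C#N)c(F)c2)cc(C)c1Oc1cc(N)nc(Nc2ccc(C#N)cc2)n1`) keeps the shared core but carries 4-cyano-3-fluorophenyl in place of 3-methylphenyl on an aromatic carbon. Each measured step swaps one substituted phenyl group for another at this same place, so all of them bear on the change. They stay small, including a 1.3-fold lower number from compound 1 to compound 2 (0.10 log units; within the scatter) as the third of them. Among the measured compounds shown here, none of the measured compounds carries a nitrile on this group, however, so the guidance is indirect.

No step beyond the scatter is therefore expected in this assay and the expected outcome is a 1.2-fold lower number from compound 3 to compound 4 (0.06 log units; within the scatter) with real uncertainty around it. For compound 4 the estimated value is 24000 nM with an expected range from 8000 nM to 60000 nM as its limits of confidence.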

Compound 4, half-maximal cytotoxic concentration: 5000 nM
Estimate against measurement, compound 4: 4.8-fold (0.68 log units) above; measured number outside the range, below it.
By their numbers in this assay, from the lowest: compound 4; then compounds 2, 3 and 1 (each within the scatter of the next).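

Until now, 2-fluorophenyl, 4-fluorophenyl and 3-methylphenyl at this place gave readings within the scatter of one another in this assay, so the position seemed indifferent to the choice of substituted phenyl group. 4-Cyano-3-fluorophenyl breaks that picture, with a 5.5-fold lower number from compound 3 to compound 4 (0.74 log units; beyond the scatter) and a 4.6-fold lower number from compound 2 to compound 4 (0.66 log units; beyond the scatter) and a 5.9-fold lower number from compound 1 to compound 4 (0.77 log units; beyond the scatter), which makes compound 4 the most toxic of the four in this test, though only modestly so. Nothing available here explains why this group stands apart.

4-Cyano-3-fluorophenyl brings a nitrile and a fluorine together, and the compounds shown do not separate the two. Going by these compounds, whether the nitrile alone is enough remains open, a question 4-cyanophenyl would address, and how an amine or a carboxylic acid on this ring would read is also unknown.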